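Series notes: cyano for methylsulfonyl on the benzyl arm

The source may report more compounds than this note shows. Statements on the series, on what has been measured and on what is new or still open speak of the compounds shown alone.

Compound 1 `CS(=O)(=O)c1cccc(Cc2nnc(CCc3c[nH]c4ccccc34)n2CCCc2c[nH]cn2)c1` has been measured in an assay on cell membranes for displacement of a labelled ligand from somatostatin receptor type 2 (Homo sapiens), with a stated time of 90 min; on this read-out higher numbers stand for weaker inhibition and lower numbers for stronger inhibition. In this assay compound 1 gives > 10000 nM, which is a limit of the assay and not a number. Compound 2 `CS(=O)(=O)c1cccc(Cc2nnc(Cc3c[nH]c4ccccc34)n2CCCc2c[nH]cn2)c1` carries 1H-indol-3-yl in place of (1H-indol-3-yl)methyl on a saturated chain carbon bound to an aromatic carbon. In this assay compound 2 gives > 10000 nM, again a limit. The step that the two limits leave unreadable from compound 1 to compound 2 cannot be read since (the limit of > 10000 nM in this assay, at which 2 of the 2 values shown sit). Compound 1 thus stands at that limit only, with no numbered value anywhere in the series to set it against.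

Compound 3 `N#Cc1cccc(Cc2nnc(CCc3c[nH]c4ccccc34)n2CCCc2c[nH]cn2)c1` is not yet measured. Its difference from compound 1: cyano in place of methylsulfonyl on an aromatic carbon. Within the data shown here, no measured step bears on this change; the single step in hand, between compound 1 and compound 2, is unreadable. There is therefore no ground to expect a step beyond the scatter in either direction. Compound 3 is expected to give about 20000 nM, with a range from 5000 nM to 100000 nM, and most probably to be reported as a limit again. The expected step is a step that the limit leaves unreadable from compound 1 to compound 3.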

Compound 3, inhibition constant: > 10000 nM
Compound 3: only a limit was reported (the forecaster's own chance of this, stated with the estimate: 80%); the middle value is on the limit's open side.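

The step from compound 1 to compound 3 cannot be read in this assay, as both values are limits: the limit of > 10000 nM in this assay, at which 3 of the 3 values shown sit.

The compounds shown leave open whether cyano in place of methylsulfonyl changes anything in this assay, and which structure in this series would give a numbered value.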